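The source may hold more compounds than are shown below. What is called first, only, known or untested is meant among the compounds shown, and "the series" means these compounds.

Measured so far in a physicochemical assay for lipophilicity; a lower number here means a more polar compound, a higher number a more lipophilic compound
compound 1 `Brc1ccc(Br)c(N(CC2CC2)C2=NCCN2)c1` (-0.52)
compound 2 `Brc1ccc(N(CC2CC2)C2=NCCN2)c(Br)c1` (-0.31)
compound 3 `C=CCN(C1=NCCN1)c1c(Br)cccc1Br` (-0.75)

Compound 3 at -0.75 lies within the scatter of compound 1 at -0.52. Compound 2 at -0.31 stands higher than compound 3, and that gap is beyond the scatter. The next compound to be measured is compound 4 (`Brc1cccc(Br)c1N(CC1CCCC1)C1=NCCN1`). Its difference from compound 3 is counted as follows (cyclopentyl in place of vinyl on a saturated chain carbon bound to a nitrogen on an aromatic ring). In words, it is cyclopentyl in place of vinyl on a saturated chain carbon bound to a nitrogen on an aromatic ring.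

For the measured compounds named here, no two measured compounds differ in one place, so the series offers no direct guide to the size of this step. The expectation rests on the carbon count of the change and on the starting value of compound 3 (-0.75). In this assay an upward move beyond the scatter is expected, and the estimated size is given here (a number 1.05 log units higher from compound 3 to compound 4 (beyond the scatter)). The estimate for compound 4 is an expected 0.3 (range -0.2 to 0.8).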

Compound 4, distribution coefficient: 0.32
Compound 4: the middle estimate sits 0.02 log units below what was measured, within the range that was stated.
By their numbers in this assay, from the lowest: compounds 3, 1 and 2 (each within the scatter of the next, the first and the last beyond it); then compound 4.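

In this assay, for the compounds shown here, cyclopentyl in place of vinyl on a saturated chain carbon bound to a nitrogen on an aromatic ring gives a number 1.07 log units higher from compound 3 to compound 4 (beyond the scatter), the first step that can be read at a single place. This position therefore carries a large change in this read-out: vinyl, with 2 carbon and a double bond outside aromatic rings, leaves, while cyclopentyl, with 5 carbon and a five-membered non-aromatic ring, enters, and neither group has hydrogen-bond donors or acceptors. No measurement at hand bears on the origin of this step.

This one pair changes carbon count, ring and double bond together, so their separate shares remain unresolved. Also open, on these data alone, is how a longer open chain, or an amine or carboxylic acid, would compare at this place.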